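The source may hold more compounds than are shown below. What is called first, only, known or untested is meant among the compounds shown, and "the series" means these compounds.

In an ADME assay on HepG2 cells (Homo sapiens) for cytotoxicity, read by CellTiter-Glo, with a stated time of 48 h (a lower number here means that less compound is tolerated, a higher number that more compound is tolerated), compound 1 (`CCCCNc1nc2cc(OC)ccc2nc1S(C)(=O)=O`) reads > 100000 nM, which is a limit of the assay and not a number. Among the compounds with values here, compound 2 (`COc1ccc2nc(S(C)(=O)=O)c(NC3CCCCC3)nc2c1`) gives 79400 nM, the only actual number so far. Compound 3 (`COc1ccc2nc(S(C)(=O)=O)c(NCC(C)C)nc2c1`) carries isobutyl in place of cyclohexyl on a nitrogen on an aromatic ring. Within the data shown here, one measured step bears on this change: an at least 1.2-fold lower number from compound 1 to compound 2 (0.10 log units; that floor lies within the scatter). On that step alone, no change beyond the scatter is expected in this assay. A reading for compound 3 could also fall at the limit of > 100000 nM in this assay, at which 1 of the 2 values shown sits. The expected step is a 1.1-fold higher number from compound 2 to compound 3 (0.05 log units; within the scatter). For compound 3 the estimate is 90000 nM, with an expected range of 45000 nM to 160000 nM.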

Compound 3, half-maximal cytotoxic concentration: 79400 nM
Estimate against measurement, compound 3: 1.1-fold (0.05 log units) above; low and high end bracket the measured number.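

In this assay, the ring of cyclohexyl and the open chain of isobutyl on the nitrogen on an aromatic ring can be compared directly, and the exchange gives no change at the digits printed from compound 2 to compound 3 (within the scatter). Isopropyl in place of propyl on a saturated chain carbon bound to a nitrogen on an aromatic ring gives an at least 1.2-fold lower number from compound 1 to compound 3 (0.10 log units; that floor lies within the scatter). For compound 1, > 100000 nM is a limit of the assay and not a number.

Going by these compounds, whether an amine or a carboxylic acid on this chain would move the reading beyond the scatter remains open. The same holds for a longer chain.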